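A few compounds are considered here, and "the series" means these few. Any claim that something is new, unique, unknown or untested is made for them only; others in the source may bear on it.

Measured so far:
compound 1, `CCCCCCCCCCc1ccc(-c2noc([C@H]3CCCN3)n2)cc1`: 12%
compound 2, `CCCCCCCCCCc1ccc(-c2noc(CC[C@@H](N)C(=O)O)n2)cc1`: 5%
compound 3, `CCCCCCCCCCc1ccc(-c2noc(CC(CN)OC(C)=O)n2)cc1`: 0%

These numbers come from an assay on HeLa cells for inhibition of sphingosine-1-phosphate transporter SPNS2 (Mus musculus), read by LC-MS, tested at 2 uM; on this read-out higher numbers stand for more inhibition at the one concentration tested (going by the name of the read-out) and lower numbers for less inhibition. Among the three, compound 3 has the lowest value; the nearest number is that of compound 2, and the gap between them, a number 5 percentage points lower from compound 2 to compound 3 (within the scatter), lies within the scatter, while the furthest is that of compound 1, and that gap, a number 12 percentage points lower from compound 1 to compound 3 (beyond the scatter), lies beyond it.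

Compound 4, `CCCCCCCCCCc1ccc(-c2noc(CCCN3CCCC3)n2)cc1`, has not yet been measured. It differs from compound 3 in one place: a group of 7 heavy atoms (6 carbon, 1 nitrogen; one five-membered non-aromatic ring with 1 hetero atom) in place of a group of 7 heavy atoms (4 carbon, 1 nitrogen, 2 oxygen; no ring), on a saturated chain carbon bound to an aromatic carbon.

For the measured compounds named here, two measured steps concern the same position on the chain. One is a number 5 percentage points lower from compound 2 to compound 3 (within the scatter), which stayed within the scatter. The other, a number 7 percentage points lower from compound 1 to compound 2 (within the scatter), also stayed within the scatter; the remaining step, a number 12 percentage points lower from compound 1 to compound 3 (beyond the scatter), was modest but beyond it. All three measured values are low, and changing the group on this chain carbon has so far moved the read-out little. The step of a number 8 percentage points higher from compound 3 to compound 4 (within the scatter) is therefore expected to be small, possibly upward, and not clearly beyond the scatter. Compound 4 is estimated at 8% in this assay, within a range from 0% to 22%.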

Compound 4, a percentage reported as inhibition, at one concentration (the size of the read-out at that concentration, not a potency): 3%
Beside the measured number, compound 4's estimate is 5 percentage points above it; the measured number falls inside the stated range.
By their numbers in this assay, from the lowest: compounds 3, 4, 2 and 1 (each within the scatter of the next, the first and the last beyond it).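

In this assay, putting the 2-(pyrrolidin-1-yl)ethyl group, with its five-membered ring and 0 hydrogen-bond donors, in place of the open-chain group with 1 hydrogen-bond donor and 1 double bond gives a number 3 percentage points higher from compound 3 to compound 4 (within the scatter), so this exchange at the saturated chain carbon bound to an aromatic carbon leaves the two compounds indistinguishable. The other two new comparisons read the same way: a number 2 percentage points lower from compound 2 to compound 4 (within the scatter) for (pyrrolidin-1-yl)methyl in place of amino(carboxy)methyl, and a number 9 percentage points lower from compound 1 to compound 4 (within the scatter) for 3-(pyrrolidin-1-yl)propyl in place of pyrrolidin-2-yl. Compound 4 therefore separates from none of the earlier compounds, and no measurement at hand accounts for this lack of separation.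

Still open, as far as these compounds go, is whether any other group on this chain, such as a guanidine or a piperidine ring, would give a reading beyond the scatter from these compounds. Because each reading comes from one concentration, these compounds also leave open how they would compare at other concentrations, and whether a change elsewhere on the shared core would matter more than this one.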